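This account rests on a few compounds, and the source may have more. Where it says the series, first, only, none or still open, it means among the compounds named here.

Working notes on the series, read throughout in a functional assay on A549 cells (Homo sapiens) for antiproliferative activity, read by MTT assay, with a stated time of 24 h; a higher number here means a weaker inhibitor, a lower number a stronger inhibitor. Compound 3 (`Cc1ccc(-c2nn(-c3ccccc3)cc2-c2nc3ccccc3n2S(=O)(=O)c2ccc(F)cc2)cc1`) gives 3240 nM and sits within the scatter of compound 1 (`Cc1ccc(-c2nn(-c3ccccc3)cc2-c2nc3ccccc3[nH]2)cc1`), which gives 4010 nM here. Compound 2 (`Cc1ccc(-c2nn(-c3ccccc3)cc2-c2nc3ccccc3n2S(=O)(=O)c2ccccc2)cc1`) gives 760 nM and stands clearly apart from both.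

The next change leads to compound 4 (`Cc1ccc(-c2nn(-c3ccccc3)cc2-c2nc3ccccc3n2S(=O)(=O)c2ccc(C(F)(F)F)cc2)cc1`): trifluoromethyl in place of fluoro on an aromatic carbon, para to a large group (trifluoromethyl in place of fluoro on an aromatic carbon). The nearest measured change at that place is fluoro in place of hydrogen, a modest step (a 4.3-fold higher number from compound 2 to compound 3 (0.63 log units; beyond the scatter)). Phenylsulfonyl in place of hydrogen on an aromatic nitrogen is also modest (a 5.3-fold lower number from compound 1 to compound 2 (0.72 log units; beyond the scatter)), while (4-fluorophenyl)sulfonyl in the same place stays within the scatter (a 1.2-fold lower number from compound 1 to compound 3 (0.09 log units; within the scatter)). For the measured compounds named here, no measured step replaces fluoro with another group, so the data give no direction for this change. The expected result in this assay is therefore no step beyond the scatter (a 1.1-fold lower number from compound 3 to compound 4 (0.03 log units; within the scatter)). Compound 4 is estimated at 3000 nM (expected range 1000 nM to 8000 nM).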

Compound 4, half-maximal inhibitory concentration: 1460 nM
The estimate for compound 4 lay 2.1-fold (0.31 log units) above the measured number; low and high end bracket the measured number.
By their numbers in this assay, from the lowest: compounds 2 and 4 (each within the scatter of the next); then compounds 3 and 1 (each within the scatter of the next).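

In the read-out of this assay, trifluoromethyl in place of fluoro on the 4-substituted phenyl gives the first measured step away from fluoro (a 2.2-fold lower number from compound 3 to compound 4 (0.35 log units; beyond the scatter)), and it runs towards a lower number. Trifluoromethyl in place of hydrogen stays within the scatter (a 1.9-fold higher number from compound 2 to compound 4 (0.28 log units; within the scatter)), whereas fluoro in place of hydrogen lies beyond it (a 4.3-fold higher number from compound 2 to compound 3 (0.63 log units; beyond the scatter)), so of these two groups only fluoro separates clearly from the unsubstituted compound 2. Nothing measured here accounts for this difference between fluoro and trifluoromethyl.

On these data alone, whether methoxy, an amine or a carboxylic acid at this place would read with compound 2 and compound 4 or with compound 3 remains open. Also open, as far as these compounds go, is how an acetyl group on the aromatic nitrogen would compare with the hydrogen of compound 1.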